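Swapping Thiophen-2-yl for Ethynyl Across Two Cores

The compounds below may be only part of what the source reports. "The series", "measured", "known", "first", "only" and "open" are said of these compounds alone.

Of the compounds shown here, three have been measured in a functional assay on HL-60 cells (Homo sapiens) for antiproliferative activity, read by XTT assay, with a stated time of 72 h; a higher number here means a weaker inhibitor, a lower number a stronger inhibitor. Compound 1 `Cc1nc(N)c2c(-c3cccs3)cn([C@@H]3O[C@H](CO)[C@@H](O)[C@H]3O)c2n1` carries a thiophen-2-yl group on its core. In this assay compound 1 gives > 20000 nM, which is a limit of the assay and not a number. Compound 3 `C#Cc1cn([C@@H]2O[C@H](CO)[C@@H](O)[C@H]2O)c2nc(C)nc(N)c12` differs from compound 1 in a single place: ethynyl in place of thiophen-2-yl on an aromatic carbon. In this assay compound 3 gives > 20000 nM, again a limit rather than a number. The step between them, a step that the two limits leave unreadable from compound 1 to compound 3, cannot be sized because of the limit of > 20000 nM in this assay, at which 3 of the 3 values shown sit.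

Compound 2 `COc1nc(N)nc2c1c(-c1cccs1)cn2[C@@H]1O[C@H](CO)[C@@H](O)[C@H]1O` keeps the thiophen-2-yl group but sits on a different core; how the two cores differ is not broken down here. In this assay compound 2 gives > 20000 nM, a limit of the assay. Compound 4 `C#Cc1cn([C@@H]2O[C@H](CO)[C@@H](O)[C@H]2O)c2nc(N)nc(OC)c12` has not yet been measured. It stands to compound 2 as compound 3 stands to compound 1, with the same change at the same place: ethynyl in place of thiophen-2-yl on an aromatic carbon.

The same change on the core of compound 1 gave a step whose size is unreadable because of the limit of > 20000 nM in this assay, at which 3 of the 3 values shown sit, so neither its direction nor its size is known. With every measured compound sitting at the limit, compound 4 is expected to stay there as well, and the estimated step that the limit leaves unreadable from compound 2 to compound 4 means no change that can be read. Compound 4 is therefore estimated at 40000 nM, most likely to be reported once more only as a limit.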

Compound 4, half-maximal inhibitory concentration: > 20000 nM
Compound 4: only a limit was reported (the forecaster's own chance of this, stated with the estimate: 85%); the middle value does not contradict the limit.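

Compound 4 also gives only a limit of the assay, so the change from compound 2 to compound 4 yields no step that can be read, for this reason: the limit of > 20000 nM in this assay, at which 4 of the 4 values shown sit. Left open is how strongly any of compounds 1, 2, 3 and 4 acts in this assay, and whether ethynyl in place of thiophen-2-yl changes that activity on either core.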